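Methyl on the piperidine ring: a small step expected

The source may report more compounds than this note shows. Statements on the series, on what has been measured and on what is new or still open speak of the compounds shown alone.

Measured compounds:
Compound 1, `O=C(O)c1csc(-n2nc(-c3ccsc3)c3ccccc32)n1`: in an assay on isolated protein for antagonist activity at prostaglandin E2 receptor EP1 subtype (Homo sapiens), read by reporter gene assay (a higher number here means a weaker inhibitor, a lower number a stronger inhibitor), compound 1 gives 30 nM.
Compound 2, `O=C(O)c1csc(-n2nc(-c3cncnc3)c3ccccc32)n1`: in this assay compound 2 gives > 100 nM, which is a limit of the assay rather than a number.
Compound 3, `O=C(O)c1csc(-n2nc(N3CCCCC3)c3ccccc32)n1`: in this assay compound 3 gives 16 nM.

Compound 3 and compound 1 sit close together, as the step of a 1.9-fold lower number from compound 1 to compound 3 (0.27 log units; within the scatter) shows. Compound 2 stands apart from both: the step of an at least 3.3-fold higher number from compound 1 to compound 2 (0.52 log units; beyond the scatter) and the step of an at least 6.2-fold lower number from compound 2 to compound 3 (0.79 log units; beyond the scatter) are both beyond the scatter, though each rests on the fact that (the limit of > 100 nM in this assay, at which 1 of the 3 values shown sits).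

Compound 4, `CC1CCN(c2nn(-c3nc(C(=O)O)cs3)c3ccccc23)CC1`, differs from compound 3 by methyl in place of hydrogen on a saturated ring carbon. Among the measured compounds shown here, none of the measured steps touches this change: each of them swaps the whole group on the aromatic carbon, whereas here the piperidine ring stays and only gains a methyl. For the measured compounds named here, no measured step therefore bears directly on the expectation, and without such a step the change is expected to stay within the scatter, in either direction. For compound 4 the estimate in this assay is 18 nM, with a range from 6 nM to 55 nM, which as a step reads a 1.1-fold higher number from compound 3 to compound 4 (0.05 log units; within the scatter).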

Compound 4, half-maximal inhibitory concentration: 32 nM
Compound 4: the middle estimate sits 1.8-fold (0.25 log units) below what was measured; measured number inside the range.
By their numbers in this assay, from the lowest: compounds 3, 1 and 4 (each within the scatter of the next). At a limit, above all of these: compound 2.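

In this assay, the first change made within the piperidine ring itself gives a 2.0-fold higher number from compound 3 to compound 4 (0.30 log units; within the scatter), so a methyl on this saturated ring carbon, three ring bonds from the ring nitrogen, produces no step beyond the scatter. The 4-methylpiperidin-1-yl group also stays close to the thiophen-3-yl group, with a 1.1-fold higher number from compound 1 to compound 4 (0.03 log units; within the scatter). The pyrimidin-5-yl group of compound 2 remains apart, with an at least 3.1-fold lower number from compound 2 to compound 4 (0.49 log units; beyond the scatter), though this step rests on a limit and not on a number: the limit of > 100 nM in this assay, at which 1 of the 4 values shown sits.

Methyl is the only group shown on this ring carbon, so one step cannot show how much room the position allows. Going by these compounds, it stays open whether a hydroxyl, an ethyl or a tert-butyl group there would also remain within the scatter of compound 3.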